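The compounds below may be only part of what the source reports. "The series", "measured", "known", "first", "only" and "open" are said of these compounds alone.

In an ADME assay on the whole organism (plasma, Mus musculus) for pharmacokinetics, at a dose of 10 mg/kg by the oral route (on this read-out lower numbers stand for lower exposure and higher numbers for higher exposure at the dose given), compound 1 `CCc1nc(C)cn2nc(-c3cc(=O)n4cc(C5CCN(C)CC5)cc(C)c4n3)cc12` gives 33000 ng.h/mL, while compound 2 `Cc1cn2cc(-c3cc(=O)n4cc(N5CCN(C)CC5)ccc4n3)cc(C)c2n1` gives 2500 ng.h/mL, the lower of the two numbers by a gap beyond the usual scatter. These two compounds differ in more than one place, so their gap cannot be tied to any single change. Compound 3 `Cc1cn2cc(-c3cc(=O)n4cc(N5CCN(C)CC5)ccc4n3)cc(F)c2n1` carries fluoro in place of methyl on an aromatic carbon of compound 2: fluoro in place of methyl on an aromatic carbon. Among the measured compounds shown here, no measured pair shows this swap, so no shift beyond the scatter is expected in this assay. The estimated change is a 1.1-fold higher number from compound 2 to compound 3 (0.05 log units; within the scatter). For compound 3 the expected value is 2800 ng.h/mL, within an estimated range of 1000 ng.h/mL to 8000 ng.h/mL.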

Compound 3, area under the concentration-time curve: 2700 ng.h/mL
Compound 3: the middle estimate sits 1.0-fold (0.02 log units) above what was measured, within the range that was stated.
By their numbers in this assay, from the lowest: compounds 2 and 3 (each within the scatter of the next); then compound 1.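

In this assay, the swap of methyl for fluoro on this aromatic carbon is a 1.1-fold higher number from compound 2 to compound 3 (0.03 log units; within the scatter) and so, at this position, ortho to a fused ring, the two groups cannot be told apart. This is the first change in a single place among the compounds shown, which the gap between compound 1 and compound 2 could not provide. Nothing on hand gives a reason for this result. On these data alone, how an amine or a longer chain would fare at this position remains open. So does whether the same swap would give a similar result on the core of compound 1.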